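The source may report more compounds than this note shows. Statements on the series, on what has been measured and on what is new or still open speak of the compounds shown alone.

Measured so far in an ADME assay on MT2 cells (Homo sapiens) for cytotoxicity; on this read-out lower numbers stand for higher toxicity in this test and higher numbers for lower toxicity in this test:
compound 1 `CC(C)=CCOc1cc(Nc2ncnc(Cl)n2)ccc1Cl` — 45000 nM
compound 2 `COc1ncnc(Nc2ccc(Cl)c(OCC=C(C)C)c2)n1` — 18000 nM

Compound 2 stands lowest of the two numbers in this assay, which on this read-out means the higher toxicity of the pair; its nearest neighbour is compound 1, and the gap is a 2.5-fold lower number from compound 1 to compound 2 (0.40 log units; beyond the scatter), a modest step for exchanging chloro for methoxy on an aromatic carbon of the shared core.

Compound 3 `CC(C)=CCOc1cc(Nc2ncnc(N)n2)ccc1Cl` has not yet been measured. It differs from compound 2 by amino in place of methoxy on an aromatic carbon, placed on an aromatic carbon of the six-membered aromatic ring with three nitrogen, between two ring nitrogen atoms, meta to a large group and opposite the ring nitrogen.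

Among the measured compounds shown here, only one measured step touches this position, the step from compound 1 to compound 2, and it was modest. It shows the read-out does respond to a change at this carbon, but gives no direction for an amino group. Expected for compound 3 is therefore a step of a 1.4-fold higher number from compound 2 to compound 3 (0.14 log units; within the scatter), most likely none beyond the scatter. The estimate for compound 3 in this assay is 25000 nM, with a range from 9000 nM to 70000 nM.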

Compound 3, half-maximal cytotoxic concentration: 48000 nM
The estimate for compound 3 lay 1.9-fold (0.28 log units) below the measured number; low and high end bracket the measured number.
By their numbers in this assay, from the lowest: compound 2; then compounds 1 and 3 (each within the scatter of the next).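

In this assay the aromatic carbon between two ring nitrogen atoms has now carried three groups, and amino in place of methoxy gives a 2.7-fold higher number from compound 2 to compound 3 (0.43 log units; beyond the scatter), a modest step that mirrors the earlier one in size but runs the opposite way. Amino in place of chloro gives a 1.1-fold higher number from compound 1 to compound 3 (0.03 log units; within the scatter), so compounds 1 and 3 cannot be told apart here, and among the three groups only methoxy, in compound 2, stands apart from the others, which means a change at this carbon does not by itself move the read-out. Nothing available gives a reason for either step.

From the compounds shown here alone, whether the separation belongs to methoxy alone or extends to other groups joined through oxygen remains open, and ethoxy, hydroxy, methylamino or dimethylamino at this carbon would address that. Also open, going by these compounds, is whether the gap between methoxy and the other two groups persists when the rest of the shared core changes, for instance with fluoro in place of the chloro on the other aromatic ring.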